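Notes on the pyridinyl swap from compound 3 to compound 4

A few compounds are considered here, and "the series" means these few. Any claim that something is new, unique, unknown or untested is made for them only; others in the source may bear on it.

Measured in a functional assay on colon cells (Homo sapiens) for antiproliferative activity; on this read-out lower numbers stand for stronger inhibition of growth and higher numbers for weaker inhibition of growth:
- compound 1 `Cc1cn2c(/C=N/NC(=N)N)c(-c3ccncc3)nc2s1`: 34700 nM
- compound 2 `Cc1cn2c(/C=N/NC(=N)N)c(-c3cccnc3)nc2s1`: 20900 nM
- compound 3 `N=C(N)N/N=C/c1c(-c2ccccn2)nc2sc(Cl)cn12`: 15100 nM

Not yet measured: compound 4 `N=C(N)N/N=C/c1c(-c2ccncc2)nc2sc(Cl)cn12`.

Compound 3 lies within the scatter of compound 2 and beyond the scatter on the lower side of compound 1. Compound 4 differs by pyridin-4-yl in place of pyridin-2-yl on an aromatic carbon, with pyridin-4-yl in place of pyridin-2-yl on an aromatic carbon. Among the measured compounds shown here, the only measured step between pyridinyl groups is a 1.7-fold lower number from compound 1 to compound 2 (0.22 log units; within the scatter), and it involves a different pair of groups. No direct comparison of this pair exists. In this assay, for the measured compounds named here, a small move toward a higher number is expected, since the one pyridin-4-yl example, compound 1, gives 34700 nM. The expected change is a 1.5-fold higher number from compound 3 to compound 4 (0.16 log units; within the scatter). For compound 4 the estimated value is 22000 nM, within an expected range of 11000 nM to 42000 nM.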

Compound 4, concentration for total growth inhibition: 27500 nM
For compound 4 the middle estimate is 1.3-fold (0.10 log units) below the measured one, within the range that was stated.
By their numbers in this assay, from the lowest: compounds 3, 2, 4 and 1 (each within the scatter of the next, the first and the last beyond it).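

In this assay, pyridin-4-yl in place of pyridin-2-yl on the shared core gives a 1.8-fold higher number from compound 3 to compound 4 (0.26 log units; within the scatter) and so does not separate this pair of groups at this aromatic carbon. With pyridin-4-yl held fixed, chloro in place of methyl gives a 1.3-fold lower number from compound 1 to compound 4 (0.10 log units; within the scatter) and does not separate these two substituents either. Nothing available bears on the reason for these values.

On these data alone, whether an amine or a carboxylic acid at the pyridinyl position would depart from these values remains open. As far as these compounds go, the chloro compound with pyridin-3-yl also remains open.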